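A few compounds are considered here, and "the series" means these few. Any claim that something is new, unique, unknown or untested is made for them only; others in the source may bear on it.

Compound 1: `Cc1nc(N2CCN(S(C)(=O)=O)CC2)nc2ccc(NC(=O)COc3ccc(Cl)cc3)cc12`
Compound 2: `Cc1nc(N2CCC(O)CC2)nc2ccc(NC(=O)COc3ccc(Cl)cc3)cc12`
Compound 3, not yet measured: `CCC1(O)CCN(c2nc(C)c3cc(NC(=O)COc4ccc(Cl)cc4)ccc3n2)CC1`

In an assay on CHO-K1 cells for displacement of a labelled ligand from melanin-concentrating hormone receptor 1 (Homo sapiens), with a stated time of 2 h (a lower number here means a stronger inhibitor, a higher number a weaker inhibitor), compound 1 gives only a limit of the assay, > 10000 nM. Compound 2 gives 150 nM in this assay, which is the only actual number shown. The other value, that of compound 1, is a limit, as the limit of > 10000 nM in this assay, at which 1 of the 2 values shown sits, records. Going by the values given here, the one measured step, an at least 66-fold lower number from compound 1 to compound 2 (1.82 log units; beyond the scatter), exchanges the whole ring attached to the shared core and says nothing directly about a small addition to that ring.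

Compound 3 differs from compound 2 by ethyl in place of hydrogen on a saturated ring carbon. Among the compounds with values here, no measured step shows what an ethyl group at this place does, so the only guide is that compound 2 already carries the 4-hydroxypiperidin-1-yl ring and sits at 150 nM. The expectation is therefore a step of about no change at the digits printed from compound 2 to compound 3 (within the scatter) in this assay, which is no change beyond the scatter, with a wide range to allow for either direction. Compound 3 is thus estimated at 150 nM, between 40 nM and 600 nM.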

Compound 3, half-maximal inhibitory concentration: 208 nM
Beside the measured number, compound 3's estimate is 1.4-fold (0.14 log units) below it; low and high end bracket the measured number.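

In this assay, the step that swapped the whole ring could not show how that ring responds to a small addition, whereas this one can: with ethyl in place of hydrogen on a saturated ring carbon, there is a 1.4-fold higher number from compound 2 to compound 3 (0.14 log units; within the scatter). So, on this one example, 4-ethyl-4-hydroxypiperidin-1-yl and 4-hydroxypiperidin-1-yl cannot be told apart in this assay, and the added ethyl group brings neither a measurable gain nor a measurable loss. Against the compound with the 4-(methylsulfonyl)piperazin-1-yl ring, the new ring shows an at least 48-fold lower number from compound 1 to compound 3 (1.68 log units; beyond the scatter), much like the first step, but that size is only a bound, as compound 1 gives a limit of the assay and not a number: the limit of > 10000 nM in this assay, at which 1 of the 3 values shown sits.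

The compounds shown leave open whether a longer chain such as butyl, or an amine or a carboxylic acid, would fit at this ring carbon as ethyl does. They also leave open what the hydroxyl group contributes, since every comparison here on this ring carbon keeps it, and a ring with ethyl alone would be needed to separate the two groups.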